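The source may report more compounds than this note shows. Statements on the series, on what has been measured and on what is new or still open speak of the compounds shown alone.

Compound 3 `O=C(O)CC(Cc1nc2cc(F)c(F)cc2[nH]1)c1ccc(Cl)cc1` gives 50% in an assay on isolated protein for inhibition of protein kinase C zeta type (Homo sapiens), read by 33P incorporation, tested at 200 uM; on this read-out higher numbers stand for a stronger effect at the one concentration tested and lower numbers for a weaker effect. Among the three compounds measured it stands second highest: compound 1 `O=C(O)CC(Cc1nc2cc(Cl)ccc2[nH]1)c1ccc(Cl)cc1` gives 70%, which lies beyond the scatter above it, and compound 2 `O=C(O)CC(Cc1nc2cc(F)ccc2[nH]1)c1ccc(Cl)cc1` gives 30%, which lies beyond the scatter below it.

Compound 4 `O=C(O)CC(Cc1nc2cc(Cl)c(F)cc2[nH]1)c1ccc(Cl)cc1` differs from compound 3 in one place: chloro in place of fluoro on an aromatic carbon.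

For the measured compounds named here, two measured steps bear on this change. The step from compound 1 to compound 2 shows that fluoro in place of chloro at this position cost a number 40 percentage points lower from compound 1 to compound 2 (beyond the scatter), a large drop; the change from compound 3 to compound 4 runs in the opposite direction, restoring chloro. The step from compound 2 to compound 3 shows that the additional fluoro that compound 4 also carries gave a number 20 percentage points higher from compound 2 to compound 3 (beyond the scatter). Taken together, a step upward beyond the scatter is expected, estimated at a number 25 percentage points higher from compound 3 to compound 4 (beyond the scatter).

Compound 4 is therefore expected to give about 75% in this assay, with a range from 55% to 95%.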

Compound 4, a percentage reported as inhibition, at one concentration (the size of the read-out at that concentration, not a potency): 85%
The estimate for compound 4 lay 10 percentage points below the measured number, and the stated range covers the measured number.
By their numbers in this assay, from the lowest: compound 2; then compound 3; then compound 1; then compound 4.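

In this assay, chloro in place of fluoro on an aromatic carbon gave a number 35 percentage points higher from compound 3 to compound 4 (beyond the scatter), so the gain from chloro seen between the two monohalogenated compounds also appears on the core that carries the second fluoro group: the same change on two cores in this assay, a number 40 percentage points lower (beyond the scatter) from compound 1 to compound 2 and a number 35 percentage points lower (beyond the scatter) from compound 4 to compound 3, 5 percentage points apart, within the scatter of two such steps. Fluoro in place of hydrogen likewise raised the number on the chloro-bearing core, giving a number 15 percentage points higher from compound 1 to compound 4 (beyond the scatter), and so its gain does not depend on which halogen occupies this position: the same change on two cores in this assay, a number 20 percentage points higher (beyond the scatter) from compound 2 to compound 3 and a number 15 percentage points higher (beyond the scatter) from compound 1 to compound 4, 5 percentage points apart, within the scatter of two such steps. Within these four compounds, the two changes therefore add up, and neither cancels the other.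

Going by these compounds, whether a bromo or a methoxy group on this aromatic carbon would match chloro remains open, as does whether these steps would hold with a primary amide in place of the carboxylic acid. Each number comes from a single concentration, so the compounds give no potency.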